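A few compounds are considered here, and "the series" means these few. Any claim that something is new, unique, unknown or untested is made for them only; others in the source may bear on it.

Among the compounds with values here, in a functional assay on MCF7 cells (Homo sapiens) for antiproliferative activity, read by MTT assay, with a stated time of 72 h (a lower number here means a stronger inhibitor, a higher number a weaker inhibitor), compound 2 `CCN(CC)CCNC(=O)Nc1nc2ccc(-c3cnc(OC)c(NS(=O)(=O)c4ccc(F)cc4)c3)cc2s1` gives 320 nM, the lowest of the two numbers measured so far. Within the data shown here, compound 1 `COc1ncc(-c2ccc3nc(NC(=O)NCCN(C)C)sc3c2)cc1NS(=O)(=O)c1ccc(F)cc1` gives 500 nM in this assay, and the single measured step, a 1.6-fold lower number from compound 1 to compound 2 (0.19 log units; within the scatter), lies within the scatter. That step concerns only the diethylamino end of the saturated chain and leaves the ((4-fluorophenyl)sulfonyl)amino part untouched. Compound 3 `CCN(CC)CCNC(=O)Nc1nc2ccc(-c3cnc(OC)c(NS(=O)(=O)c4ccc(C)cc4)c3)cc2s1` differs from compound 2 at exactly one place: methyl in place of fluoro on an aromatic carbon. Among the measured compounds shown here, no measured step bears on an exchange at this aromatic carbon, so nothing in the data points to a gain or a loss there. Compound 3 is therefore expected to give a step of no change at the digits printed from compound 2 to compound 3 (within the scatter), that is none beyond the scatter, with the range widened for the lack of a guiding precedent. Compound 3 is estimated at 320 nM in this assay, between 110 nM and 950 nM.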

Compound 3, half-maximal inhibitory concentration: 170 nM
Beside the measured number, compound 3's estimate is 1.9-fold (0.27 log units) above it, and the stated range covers the measured number.
By their numbers in this assay, from the lowest: compounds 3, 2 and 1 (each within the scatter of the next, the first and the last beyond it).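

In this assay, within the data shown here, methyl in place of fluoro on the aromatic carbon para to a large group gives a 1.9-fold lower number from compound 2 to compound 3 (0.27 log units; within the scatter) and is the first exchange read at this position. The position therefore carries either group without a step beyond the scatter, so 4-methylphenyl and 4-fluorophenyl cannot be told apart here. This reading holds only for the diethylamino end of the chain, and no measurement at hand offers an explanation for it.

The compounds shown leave open whether a chlorine, a methoxy, a trifluoromethyl or an amine on this carbon would give a step beyond the scatter. They also leave open whether the same exchange would read alike with the dimethylamino end of compound 1.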